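A few compounds are considered here, and "the series" means these few. Any claim that something is new, unique, unknown or untested is made for them only; others in the source may bear on it.

Three compounds sharing one core, and differing in a single group on an aromatic carbon, have been measured in an ADME assay on L02 cells (Homo sapiens) for cytotoxicity, read by MTT assay, with a stated time of 24 h; a higher number here means that more compound is tolerated, a lower number that less compound is tolerated. Compound 1 `CC1(C)[C@H]2CC[C@]1(C)N(Cc1cn(-c3ccccc3C#N)nn1)C(=O)C2` gives 46100 nM, compound 2 `CC1(C)[C@H]2CC[C@]1(C)N(Cc1cn(-c3ccccc3F)nn1)C(=O)C2` gives 13300 nM, and compound 3 `CC1(C)[C@H]2CC[C@]1(C)N(Cc1cn(-c3ccccc3Cl)nn1)C(=O)C2` gives 20100 nM. The standing of compound 3 rests on two steps: a 1.5-fold higher number from compound 2 to compound 3 (0.18 log units; within the scatter), and a 2.3-fold lower number from compound 1 to compound 3 (0.36 log units; beyond the scatter).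

Compound 4 `CC1(C)[C@H]2CC[C@]1(C)N(Cc1cn(-c3ccccc3)nn1)C(=O)C2` carries a single change, hydrogen in place of chloro on an aromatic carbon, ortho to a large group. Going by the values given here, no measured step brings in hydrogen at this place, so the evidence is indirect. The closest guide is the exchange of one group for another at the same carbon. Leaving the nitrile gave modest steps, a 3.5-fold lower number from compound 1 to compound 2 (0.54 log units; beyond the scatter), and the exchange between the two halogens stayed within the scatter. The expected outcome in this assay is a 1.1-fold higher number from compound 3 to compound 4 (0.04 log units; within the scatter), with no clear step in either direction. Compound 4 is estimated at 22000 nM, with an expected range from 10000 nM to 50000 nM.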

Compound 4, half-maximal cytotoxic concentration: 6230 nM
Estimate against measurement, compound 4: 3.5-fold (0.55 log units) above; measured number outside the range, below it.
By their numbers in this assay, from the lowest: compound 4; then compounds 2 and 3 (each within the scatter of the next); then compound 1.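

Hydrogen at this carbon gives the lowest number in this assay, and all three steps to it lie beyond the scatter: a 3.2-fold lower number from compound 3 to compound 4 (0.51 log units; beyond the scatter), a 2.1-fold lower number from compound 2 to compound 4 (0.33 log units; beyond the scatter) and a 7.4-fold lower number from compound 1 to compound 4 (0.87 log units; beyond the scatter). The earlier compounds shown here only compared groups with one another, whereas these steps show that nitrile, fluoro and chloro each go with more compound tolerated than hydrogen does, and the two halogens, though within the scatter of each other, both stand clear of it. No measurement bearing on the reason for this is available.

From the compounds shown here alone, whether an amine, a methoxy group or a carboxylic acid at this carbon would also stand above hydrogen remains open. So does whether this order of the four compounds would hold in any other test.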